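Swapping Acetyl for Benzoyl on Compound 1

The compounds below may be only part of what the source reports. "The series", "measured", "known", "first", "only" and "open" are said of these compounds alone.

Compound 1 `CC(=O)OCCSC[C@H]1CN(C)CC[C@H]1c1ccc(Cl)cc1` was tested in an assay on a subcellular fraction from brain with Norepinephrine transporter (Rattus norvegicus) as the target (on this read-out lower numbers stand for stronger inhibition and higher numbers for weaker inhibition), and gives 610 nM. Among the three compounds measured, compound 1 holds the second highest number. Its mirror image, compound 2 `CC(=O)OCCSC[C@@H]1CN(C)CC[C@@H]1c1ccc(Cl)cc1`, gives 30 nM; the step of a 20-fold lower number from compound 1 to compound 2 (1.31 log units; beyond the scatter) is large and rests on (the fact that compounds 1 and 2 differ only in the configuration as drawn). Compound 3 `CN1CC[C@@H](c2ccc(Cl)cc2)[C@@H](CSCC(=O)Nc2ccccc2)C1` carries a different arm on the same core and gives 1060 nM, a number close to that of compound 1.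

Compound 4 `CN1CC[C@@H](c2ccc(Cl)cc2)[C@@H](CSCCOC(=O)c2ccccc2)C1` is made from compound 1 by one change: phenyl in place of methyl on a carbonyl carbon. Within the data shown here, no measured step touches this carbonyl carbon; the only recorded step concerns configuration, so it offers no direct guidance on the present change. What can be said is that compound 1 and compound 3, which differ out on this arm, show numbers within the usual scatter of each other. Compound 4 is therefore expected to stay near compound 1, with a step of a 1.1-fold higher number from compound 1 to compound 4 (0.06 log units; within the scatter) that is not expected to pass beyond the scatter. The estimate for compound 4 is 700 nM, with a range from 200 nM to 2500 nM.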

Compound 4, inhibition constant: 143 nM
Estimate against measurement, compound 4: 4.9-fold (0.69 log units) above, outside the stated range (below it).
By their numbers in this assay, from the lowest: compound 2; then compound 4; then compounds 1 and 3 (each within the scatter of the next).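

In this assay, among these compounds, the change from acetyl to benzoyl gives a 4.3-fold lower number from compound 1 to compound 4 (0.63 log units; beyond the scatter) and is the first recorded step that is not one of configuration. It shows that this end of the arm is not a silent place: replacing methyl with phenyl on the carbonyl carbon, with no other difference, moves the number towards stronger inhibition. Phenyl brings six heavy atoms and an aromatic ring in place of the single carbon of methyl, yet nothing on record explains why this swap strengthens inhibition.

From the compounds shown here alone, it remains open whether ethyl, cyclohexyl or a pyridyl ring on the same carbonyl carbon would follow phenyl or stay with methyl. Also open, going by these compounds, is how large the same swap from acetyl to benzoyl would be on compound 2, the mirror image of compound 1.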